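This account rests on a few compounds, and the source may have more. Where it says the series, first, only, none or still open, it means among the compounds named here.

In an ADME assay on Vero cells (Chlorocebus sabaeus) for cytotoxicity, read by resazurin assay, with a stated time of 72 h (on this read-out lower numbers stand for stronger inhibition and higher numbers for weaker inhibition), compound 3 (`COc1ccc(C(=O)CCN2CCN(c3ccc(Cl)cc3)CC2)cc1OC`) gives 185000 nM. Within the data shown here, compound 2 (`COc1ccc(C(=O)CCN2CCN(c3ccc(C(F)(F)F)cc3)CC2)cc1OC`) gives 243000 nM, a value within the scatter of the one for compound 3, while compound 1 (`COc1ccc(C(=O)CCN2CCN(c3ccc([N+](=O)[O-])cc3)CC2)cc1`) gives 587000 nM, which lies beyond the scatter of compound 3.

Compound 4 (`COc1ccc(C(=O)CCN2CCN(c3ccc([N+](=O)[O-])cc3)CC2)cc1OC`) differs from compound 3 by nitro in place of chloro on an aromatic carbon, para to a large group: nitro in place of chloro on an aromatic carbon. Among the measured compounds shown here, only one measured step involves a swap at this place, a 1.3-fold lower number from compound 2 to compound 3 (0.12 log units; within the scatter), with chloro in place of trifluoromethyl, and it stays within the scatter. For the measured compounds named here, compound 1 also carries nitro but differs from compound 4 elsewhere, so it gives no direct step. Even so, compound 1 with 587000 nM tilts the expectation slightly upward.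

A small rise, not clearly beyond the scatter, is therefore expected in this assay. The estimate amounts to an expected 1.4-fold higher number from compound 3 to compound 4 (0.15 log units; within the scatter). For compound 4 the expected value is 260000 nM, with an estimated range of 130000 nM to 560000 nM.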

Compound 4, half-maximal inhibitory concentration: 105000 nM
Estimate against measurement, compound 4: 2.5-fold (0.39 log units) above; the measured number lies below the stated range.
By their numbers in this assay, from the lowest: compounds 4, 3 and 2 (each within the scatter of the next, the first and the last beyond it); then compound 1.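

At the aromatic carbon para to a large group, this assay does not separate nitro from chloro, since a 1.8-fold lower number from compound 3 to compound 4 (0.25 log units; within the scatter) stays within the scatter, but a 2.3-fold lower number from compound 2 to compound 4 (0.36 log units; beyond the scatter) lies beyond it and gives this place its first modest separation between two groups. With nitro held fixed, methoxy in place of hydrogen on an aromatic carbon gives a 5.6-fold lower number from compound 1 to compound 4 (0.75 log units; beyond the scatter) and so shows that a second place on the shared core also moves the number. Nothing on hand accounts for either step.

The compounds shown leave open whether an amine or a carboxylic acid at the para place would stay with these three groups or move away from them. They also leave open whether the methoxy step would be of the same size with chloro or trifluoromethyl in place of nitro.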